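A Hydroxy Group Tested Against the Bare Phenyl

The source may report more compounds than this note shows. Statements on the series, on what has been measured and on what is new or still open speak of the compounds shown alone.

Compound 1: `COc1cccc(C(C)Sc2nc3c(cnn3C)c(=O)n2-c2ccccc2)c1` — in an assay on isolated protein for inhibition of aldehyde dehydrogenase 1A1 (Homo sapiens) (a higher number here means a weaker inhibitor, a lower number a stronger inhibitor), compound 1 gives 451 nM.
Compound 2: `CC(Sc1nc2c(cnn2C)c(=O)n1-c1ccccc1)c1ccccc1` — in this assay compound 2 gives 130 nM.

Among the two numbers in this assay, compound 2 holds the lower one; its only neighbour is compound 1, and the single measured step is a 3.5-fold lower number from compound 1 to compound 2 (0.54 log units; beyond the scatter). Compound 3, `CC(Sc1nc2c(cnn2C)c(=O)n1-c1ccccc1)c1cccc(O)c1`, is not yet measured. It differs from compound 2 by hydroxy in place of hydrogen on an aromatic carbon. Within the data shown here, no measured pair introduces a hydroxy group, so the change can only be read against the one step that removes a substituent from that phenyl, a 3.5-fold lower number from compound 1 to compound 2 (0.54 log units; beyond the scatter), where the bare ring gave the lower number. A hydroxy is a different group from a methoxy, so that step is a guide of limited weight. Compound 3 is therefore expected to give a somewhat higher number than compound 2, a step of a 1.9-fold higher number from compound 2 to compound 3 (0.28 log units; within the scatter), smaller than the one seen for the methoxy and possibly within the scatter. The estimate for compound 3 is 250 nM, with a range from 100 nM to 700 nM.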

Compound 3, half-maximal inhibitory concentration in the aldehyde dehydrogenase 1A1 assay: 130 nM
Compound 3: the middle estimate sits 1.9-fold (0.28 log units) above what was measured; measured number inside the range.
By their numbers in the aldehyde dehydrogenase 1A1 assay, from the lowest: compounds 2 and 3 (each within the scatter of the next); then compound 1.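

At the place on the ring meta to a large group, hydroxy in place of hydrogen costs nothing measurable in the aldehyde dehydrogenase 1A1 assay, with no change at the digits printed from compound 2 to compound 3 (within the scatter), while the link to the methoxy compound reads a 3.5-fold lower number from compound 1 to compound 3 (0.54 log units; beyond the scatter), so an oxygen on this carbon does not by itself go with the higher number that compound 1 gives. The earlier compounds shown here also gave no view of a second property, and in a physicochemical assay for solubility, using the shake flask method, in phosphate buffer, with a stated time of 24 h, at pH 7.4 (on this read-out higher numbers stand for higher solubility and lower numbers for lower solubility), compound 2 gives 8000 nM and compound 3 gives 21000 nM, a result that reads a 2.6-fold higher number from compound 2 to compound 3 (0.42 log units; beyond the scatter). The hydroxy group therefore leaves the number in the aldehyde dehydrogenase 1A1 assay where it stood while going with a measured gain in solubility: the measured solubility of compound 2, 8000 nM, and of compound 3, 21000 nM, a 2.6-fold higher number (0.42 log units; beyond the scatter)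

The compounds shown leave open whether an amine or a carboxylic acid at this same place would also hold the number in the aldehyde dehydrogenase 1A1 assay, and how either would read in the physicochemical assay. They also leave open whether a hydroxy group on another carbon of this ring would behave as it does here.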